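Phenyl to 2-fluorophenyl in the series of compound 1

The source may hold more compounds than are shown below. What is called first, only, known or untested is meant among the compounds shown, and "the series" means these compounds.

Among the measured compounds shown here, compound 1 (`O=C(CCc1ccccc1)Nc1nc2ccccc2c(=O)s1`) is the one compound of the pair with a numeric reading: in an assay on CHO cells for displacement of a labelled ligand from adenosine receptor A2b (Homo sapiens), read by scintillation counting, with a stated time of 75 min (a higher number here means a weaker inhibitor, a lower number a stronger inhibitor), compound 1 gives 365 nM. Compound 2 (`Cc1sc2nc(NC(=O)CCCc3ccccc3)sc(=O)c2c1C`) carries a different core. In this assay compound 2 gives > 1000 nM, which is a limit of the assay and not a number (the limit of > 1000 nM in this assay, at which 1 of the 2 values shown sits). No step between two measured compounds differing in a single place is available, so compound 1 stands alone on the numbers shown, and nothing measured bears directly on the change to compound 3.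

Compound 3 (`O=C(CCc1ccccc1F)Nc1nc2ccccc2c(=O)s1`) differs from compound 1 by one change: fluoro in place of hydrogen on an aromatic carbon, or, read one bond further out, phenyl to 2-fluorophenyl. For a single fluorine on that ring, the expected step from compound 1 to compound 3 in this assay, a 1.2-fold lower number from compound 1 to compound 3 (0.09 log units; within the scatter), is small and is not expected to reach beyond the usual scatter in either direction. Compound 3 is therefore estimated at 300 nM, with a range from 120 nM to 800 nM.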

Compound 3, inhibition constant: 801 nM
Compound 3: the middle estimate sits 2.7-fold (0.43 log units) below what was measured, and the stated range ends below it.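

Working notes on the phenyl ring of the series of compound 1: in this assay, the first single-place step in the series comes from fluoro in place of hydrogen on an aromatic carbon, ortho to a large group, and gives a 2.2-fold higher number from compound 1 to compound 3 (0.34 log units; beyond the scatter) as a modest change beyond the scatter. This position is therefore not silent to a single added fluorine, and on this one example the replacement of hydrogen weakens the inhibitor rather than strengthening it. No evidence shown here bears on what lies behind this step.

A single substituent at a single place cannot show whether the loss is tied to this carbon or to fluoro itself, so a fluoro on another carbon of the same ring, or a chloro or methoxy group on this same carbon, would be needed to separate the two. Also open, from the compounds shown here alone, is whether the step carries over to a longer chain on the shared core, where a 2-fluorophenyl end would test the same change at a different distance from the amide.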